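A few compounds are considered here, and "the series" means these few. Any claim that something is new, unique, unknown or untested is made for them only; others in the source may bear on it.

Measured so far:
compound 1, `COc1cc(-c2cc(/C=C/C(=O)c3ccc(Cl)c(Cl)c3)[nH]n2)cc(OC)c1OC`, with 103% in a functional assay on MDA-MB-231 cells (Homo sapiens) for cytotoxicity, read by sulforhodamine B assay, with a stated time of 48 h, tested at 0.01 uM; a lower number here means a stronger effect, a higher number a weaker effect of the compound at the concentration tested
compound 2, `COc1ccc(C(=O)/C=C/c2cc(-c3cc(OC)c(OC)c(OC)c3)n[nH]2)cc1OC`, with 104% in this assay

Compound 2 gives the higher of the two numbers in this assay, but its nearest neighbour is compound 1, and the step of a number 1 percentage points higher from compound 1 to compound 2 (within the scatter) lies within the scatter, so the two cannot be ordered. Compound 3, `COc1ccc(C(=O)/C=C/c2cc(-c3cc(OC)c(OC)c(OC)c3)n[nH]2)cc1`, differs from compound 2 by a single change: hydrogen in place of methoxy on an aromatic carbon. Among the compounds with values here, no measured pair shows this exact change. Within the data shown here, the only step on record, a number 1 percentage points higher from compound 1 to compound 2 (within the scatter), alters the same ring on the carbonyl carbon but swaps the whole substitution pattern, and it left the read-out unchanged within the scatter. Among the measured compounds shown here, with both measured values close together and no precedent for removing one methoxy, compound 3 is expected to stay near compound 2, with a number 1 percentage points lower from compound 2 to compound 3 (within the scatter) and no step beyond the scatter. Compound 3 is therefore estimated at 103%, within 90% to 115%.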

Compound 3, a percentage reported as activity, at one concentration (the size of the read-out at that concentration, not a potency): 104%
Beside the measured number, compound 3's estimate is 1 percentage points below it; the measured number falls inside the stated range.
By their numbers in this assay, from the lowest: compounds 1, 2 and 3 (each within the scatter of the next).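

In this assay, within the data shown here, there is no change at the digits printed from compound 2 to compound 3 (within the scatter) when 3,4-dimethoxyphenyl gives way to 4-methoxyphenyl, the first direct reading of hydrogen in place of methoxy on this aromatic carbon, ortho to a methoxy group. There is likewise a number 1 percentage points higher from compound 1 to compound 3 (within the scatter) when 3,4-dichlorophenyl gives way to 4-methoxyphenyl on the carbonyl carbon, so the three aryl groups seen there all read alike in this assay at this single concentration. Nothing measured here accounts for this sameness.

As far as these compounds go, whether a different kind of group on this ring, such as an amine or a carboxylic acid, would move the read-out stays open. So does the question of whether these three compounds would separate at a higher concentration, which a reading at one concentration cannot tell.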